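Imine side chain: hydroxy in place of ethyl

A few compounds are considered here, and "the series" means these few. Any claim that something is new, unique, unknown or untested is made for them only; others in the source may bear on it.

Within the data shown here, compound 2 `CCCCC/N=C(\C)c1c(O)c2ccccc2oc1=O` gives 6700 nM in an assay on isolated protein for inhibition of myosin-2 (Bos taurus), read by spectrophotometry, with a stated time of 24 min (on this read-out higher numbers stand for weaker inhibition and lower numbers for stronger inhibition), the higher of the two numbers so far; compound 1 `C/C(=N\Cc1cccc(C)c1)c1c(O)c2ccccc2oc1=O` gives 4900 nM, and the step of a 1.4-fold higher number from compound 1 to compound 2 (0.14 log units; within the scatter) stays within the scatter. Compound 3 `C/C(=N\CCCO)c1c(O)c2ccccc2oc1=O` awaits measurement. It differs from compound 2 by hydroxy in place of ethyl on a saturated chain carbon, three bonds along the chain from a double-bonded nitrogen. Among the measured compounds shown here, only the step from compound 1 to compound 2 touches this side chain, and it was within the scatter; no measured step brings in a hydroxy, so nothing here points beyond the scatter. Compound 3 is therefore expected at 8000 nM, range 2500 nM to 25000 nM. The expected step is a 1.2-fold higher number from compound 2 to compound 3 (0.08 log units; within the scatter).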

Compound 3, half-maximal inhibitory concentration: 37000 nM
Estimate against measurement, compound 3: 4.6-fold (0.67 log units) below, outside the stated range (above it).
By their numbers in this assay, from the lowest: compounds 1 and 2 (each within the scatter of the next); then compound 3.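

In this assay, among these compounds, hydroxy in place of ethyl gives a 5.5-fold higher number from compound 2 to compound 3 (0.74 log units; beyond the scatter) and is the first change on this side chain to go beyond the scatter. The side chain of compound 1 leads to the same reading: 2-hydroxyethyl in place of 3-methylphenyl gives a 7.6-fold higher number from compound 1 to compound 3 (0.88 log units; beyond the scatter) at this position, so the position is not indifferent to what the chain carries. No evidence on hand bears on the reason for this result.

Still open, on these data alone, is whether the step follows the hydroxy entering or the ethyl leaving. A plain propyl chain, or a methoxy or an amine at the chain end, would separate the two.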